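Swapping phenethyl for piperidin-4-yl in a cytotoxicity series

A few compounds are considered here, and "the series" means these few. Any claim that something is new, unique, unknown or untested is made for them only; others in the source may bear on it.

Measured so far:
Compound 1, `COc1ccc(-c2cnc(NC(=O)CCc3ccccc3)n2C)cc1`, in a toxicity assay on THP-1 cells (Homo sapiens) for inhibition (a higher number here means that more compound is tolerated, a lower number that less compound is tolerated), compound 1 gives > 100000 nM.
Compound 2, `COc1ccc(-c2cnc(NC(=O)c3ccc(F)cc3)n2-c2ccccc2)cc1`, in this assay compound 2 gives 8800 nM.

The value of compound 1 is a limit of the assay, not a number: the limit of > 100000 nM in this assay, at which 1 of the 2 values shown sits. For the measured compounds named here, compound 1 therefore stands at the tolerated end of what has been measured, while compound 2 is the only compound with a numeric value. Going by the values given here, no step between these two is recorded, so only their two values can be compared.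

Compound 3, `COc1ccc(-c2cnc(NC(=O)C3CCNCC3)n2C)cc1`, is not yet measured. It differs from compound 1 in one place: piperidin-4-yl in place of phenethyl on a carbonyl carbon. Since compound 1 already sits at a limit in this assay, no step beyond the scatter is expected, and the outcome is likely to be another limit rather than a number. The expected step is a number no higher from compound 1 to compound 3 (the limit leaves the size open). Compound 3 is estimated at 100000 nM, with a range from 30000 nM to 300000 nM.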

Compound 3, half-maximal cytotoxic concentration: > 100000 nM
Compound 3 ended at the assay's limit; the forecaster's own chance of this, stated with the estimate: 70%; the middle value lies on the limit itself.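

Compound 1 and compound 3 both end at a limit of the assay rather than at a number, so no step between them can be read: the limit of > 100000 nM in this assay, at which 2 of the 3 values shown sit.

Going by these compounds, what stays open is how much of either compound is tolerated in this assay, and whether piperidin-4-yl and phenethyl differ there at all.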